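The source may hold more compounds than are shown below. What is called first, only, known or untested is meant among the compounds shown, and "the series" means these compounds.

Measured so far:
compound 1 `CCO/N=C(\CCN1CCN(c2cccc(OC)c2)CC1)c1ccccc1`, value 2680 nM
compound 2 `CCO/N=C(\CCN1CCN(c2ncccc2C)CC1)c1ccccc1`, value 253 nM

Both compounds were tested in a functional assay on HEK293 cells with D(4) dopamine receptor (Homo sapiens) as the target, read by FLIPR; on this read-out lower numbers stand for an effect already at smaller amounts and higher numbers for an effect only at larger amounts of compound. Compound 2 holds the lowest of the two numbers shown; the nearest is compound 1, and the only step recorded between them, an 11-fold lower number from compound 1 to compound 2 (1.03 log units; beyond the scatter), is large and well beyond the scatter, so compound 2 acts at clearly smaller amounts than compound 1.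

Compound 3 `CCO/N=C(\CCN1CCN(c2ncccn2)CC1)c1ccccc1` is not yet measured. It differs from compound 2 in one place: pyrimidin-2-yl in place of 3-methylpyridin-2-yl on an amine nitrogen in a ring. The methyl group is lost and a second ring nitrogen enters, so the group on the ring amine nitrogen becomes smaller and carries one more hydrogen-bond acceptor.

For the measured compounds named here, the one measured step, from compound 1 to compound 2, swapped a methoxyphenyl for a methylpyridinyl and gave a large gain. It does not tell how the pyrimidinyl will behave, only that this position is sensitive. Going by the values given here, with no step of the same kind to lean on, a modest shift toward higher numbers is expected, roughly a 2.4-fold higher number from compound 2 to compound 3 (0.38 log units; beyond the scatter) for compound 3. Compound 3 is therefore estimated at 600 nM, with a range from 200 nM to 2000 nM.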

Compound 3, half-maximal effective concentration: 615 nM
The estimate for compound 3 lay 1.0-fold (0.01 log units) below the measured number; the range from low to high includes it.
By their numbers in this assay, from the lowest: compound 2; then compound 3; then compound 1.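

Swapping in pyrimidin-2-yl on the amine nitrogen in the ring gives, in this assay, a 2.4-fold higher number from compound 2 to compound 3 (0.39 log units; beyond the scatter) and so gives up part of the gain seen with 3-methylpyridin-2-yl, but not all of it, as a 4.4-fold lower number from compound 1 to compound 3 (0.64 log units; beyond the scatter) shows. Until now a single pair of groups marked this position as sensitive; with a third group, both rings that carry ring nitrogen sit at lower numbers than the 3-methoxyphenyl ring, and none of the three compounds goes against this order, though three compounds are a narrow base for any rule. No measurement at hand explains why these groups differ in this way.

From the compounds shown here alone, the step from compound 2 to compound 3 loses a methyl group and adds a second ring nitrogen at once, so the share of each in the shift stays unknown, and a plain pyridin-2-yl group would stand between the two and could separate them. Going by these compounds, whether a larger group in place of that methyl, such as the ethyl of 3-ethylpyridin-2-yl, would bring the number lower or higher also remains open.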